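This account rests on a few compounds, and the source may have more. Where it says the series, first, only, none or still open, it means among the compounds named here.

The measured compounds in a functional assay on HCT-116 cells (Homo sapiens) for antiproliferative activity, read by MTT assay; on this read-out lower numbers stand for stronger inhibition and higher numbers for weaker inhibition:
compound 1, `CNC(=O)c1ccc(Oc2cccc(NC(=S)Nc3ccc(C)cc3)c2)nc1`, gives 53700 nM.
compound 2, `CNC(=O)c1ccc(Oc2cccc(NC(=S)Nc3ccc(C)c(C)c3)c2)nc1`, gives 48200 nM.
compound 3, `CNC(=O)c1ccc(Oc2cccc(NC(=S)Nc3ccc(F)c(C(F)(F)F)c3)c2)nc1`, gives 19000 nM.

Compound 1 stands with the highest of the three numbers in this assay. Compound 2 lies nearest, within the scatter; compound 3 lies furthest, and the gap between its value and that of compound 1 is beyond the scatter.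

Compound 4, `CNC(=O)c1ccc(Oc2cccc(NC(=S)Nc3ccc(OC(F)(F)F)cc3)c2)nc1`, has not yet been measured. It differs from compound 1 in one place: trifluoromethoxy in place of methyl on an aromatic carbon.

For the measured compounds named here, only one measured step bears on this change, namely a 1.1-fold lower number from compound 1 to compound 2 (0.05 log units; within the scatter), which adds a methyl to the same ring and stays within the scatter. Going by the values given here, no measured step exchanges methyl for trifluoromethoxy. Among the compounds with values here, compound 3, which carries fluorine-bearing groups on that ring, is the only compound whose value sits beyond the scatter from compound 1, and it lies on the lower side. Compound 4 is therefore expected to give a modest step toward lower numbers in this assay, of about a 1.8-fold lower number from compound 1 to compound 4 (0.25 log units; within the scatter). The estimate for compound 4 is 30000 nM, within a range from 12000 nM to 75000 nM.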

Compound 4, half-maximal inhibitory concentration: 54700 nM
For compound 4 the middle estimate is 1.8-fold (0.26 log units) below the measured one, and the stated range covers the measured number.
By their numbers in this assay, from the lowest: compound 3; then compounds 2, 1 and 4 (each within the scatter of the next).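

In this assay, trifluoromethoxy in place of methyl on an aromatic carbon, para to a large group, gives a 1.0-fold higher number from compound 1 to compound 4 (0.01 log units; within the scatter), so at this position a group of 5 heavy atoms that includes a hydrogen-bond acceptor gives a number that cannot be told from that of the methyl group, with 1 heavy atom and no acceptor. The earlier step, a 1.1-fold lower number from compound 1 to compound 2 (0.05 log units; within the scatter), added a methyl on the same ring and also stayed within the scatter, but it did not exchange the group at this position. No measurement offered here accounts for this result.

The compounds shown leave open whether an amine, a carboxylic acid or a longer chain at this position would shift the number beyond the scatter. They also leave open how trifluoromethoxy would behave with a second group on the same ring.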